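The source may report more compounds than this note shows. Statements on the series, on what has been measured and on what is new or still open speak of the compounds shown alone.

Compound 2 `CC(=O)Nc1ccc(-c2nc3cc(C(F)(F)F)ccc3[nH]2)cc1` carries the shared core with an acetamido group. Among the compounds with values here, in an ADME assay on BHK cells (Mesocricetus auratus) for cytotoxicity, read by MTT assay, with a stated time of 96 h (on this read-out lower numbers stand for higher toxicity in this test and higher numbers for lower toxicity in this test), compound 2 gives 53000 nM, the only plain number among the values shown for the series. Compound 1 `O=C(O)CCC(=O)Nc1ccc(-c2nc3cc(C(F)(F)F)ccc3[nH]2)cc1` bears a carboxymethyl group on the saturated chain carbon bound to the carbonyl carbon. In this assay compound 1 is reported only as a limit, > 100000 nM; this is the limit of > 100000 nM in this assay, at which 1 of the 2 values shown sits. The step of an at least 1.8-fold lower number from compound 1 to compound 2 (0.27 log units; that floor lies within the scatter) has a floor that lies within the scatter and so gives no clear direction for substitution at this place.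

Compound 3 `O=C(CN1CCCC1)Nc1ccc(-c2nc3cc(C(F)(F)F)ccc3[nH]2)cc1` differs from compound 2 by pyrrolidin-1-yl in place of hydrogen on a saturated chain carbon bound to a carbonyl carbon. Within the data shown here, the one measured step at this place, an at least 1.8-fold lower number from compound 1 to compound 2 (0.27 log units; that floor lies within the scatter), is small, so a change of no more than the scatter is expected for compound 3, a 1.1-fold lower number from compound 2 to compound 3 (0.03 log units; within the scatter). For compound 3 the expected value in this assay is 50000 nM, within 20000 nM to 150000 nM.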

Compound 3, half-maximal cytotoxic concentration: 29000 nM
For compound 3 the middle estimate is 1.7-fold (0.24 log units) above the measured one, and the stated range covers the measured number.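

In this assay, pyrrolidin-1-yl in place of hydrogen on the saturated chain carbon bound to a carbonyl carbon gives a 1.8-fold lower number from compound 2 to compound 3 (0.26 log units; within the scatter), so this ring brings no clear shift relative to the plain acetamido group. Within the data shown here, the other step at this place, an at least 3.4-fold lower number from compound 1 to compound 3 (0.53 log units; beyond the scatter), is the first to clear the scatter and points towards higher toxicity in this test with pyrrolidin-1-yl than with carboxymethyl, though only as a floor. Compound 1 is reported only as a limit: the limit of > 100000 nM in this assay, at which 1 of the 3 values shown sits.

Open, as far as these compounds go, is whether an acyclic amine such as dimethylamino, or a six-membered ring such as piperidin-1-yl or morpholin-4-yl, reads like pyrrolidin-1-yl at this carbon. Also open, from the compounds shown here alone, is how a shorter or longer chain ending in a carboxylic acid would read here.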